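Acyl variation on the piperazine amide: solubility notes

The compounds below may be only part of what the source reports. "The series", "measured", "known", "first", "only" and "open" are said of these compounds alone.

Measured compounds:
compound 1 `O=C(c1ccccc1F)N1CCN(c2nc(=O)c3cc(C(F)(F)F)cc([N+](=O)[O-])c3s2)CC1` — 3.1 ug/mL
compound 2 `CC(=O)N1CCN(c2nc(=O)c3cc(C(F)(F)F)cc([N+](=O)[O-])c3s2)CC1` — 83.9 ug/mL
compound 3 `O=C(C1CCCC1)N1CCN(c2nc(=O)c3cc(C(F)(F)F)cc([N+](=O)[O-])c3s2)CC1` — 5.34 ug/mL

All three share the same core and differ only in the group on the carbonyl carbon of the piperazine amide. In a physicochemical assay for solubility, read by HPLC (on this read-out lower numbers stand for lower solubility and higher numbers for higher solubility), compound 2 gives 83.9 ug/mL, the highest number of the three. Compound 3 sits second of the three numbers; it lies nearest to compound 1 3.1 ug/mL and furthest from compound 2, as the steps show: a 1.7-fold higher number from compound 1 to compound 3 (0.24 log units; within the scatter) and a 16-fold lower number from compound 2 to compound 3 (1.20 log units; beyond the scatter).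

Compound 4 `CCC(=O)N1CCN(c2nc(=O)c3cc(C(F)(F)F)cc([N+](=O)[O-])c3s2)CC1` has not yet been measured in this assay. Against compound 3 the change is ethyl in place of cyclopentyl on a carbonyl carbon. Among the compounds with values here, the steps that bear on this are the large one seen in a 16-fold lower number from compound 2 to compound 3 (1.20 log units; beyond the scatter) and a 27-fold higher number from compound 1 to compound 2 (1.43 log units; beyond the scatter), where moving to the smallest acyl group brought the largest number. The ethyl group of compound 4 lies between methyl and cyclopentyl in the count of carbon atoms, so a rise from compound 3 is expected, though a smaller one than the full step back to compound 2; the expected step is a 6.6-fold higher number from compound 3 to compound 4 (0.82 log units; beyond the scatter). For compound 4 the estimated solubility in this assay is 35 ug/mL, with an expected range of 12 ug/mL to 90 ug/mL.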

Compound 4, solubility: 3.29 ug/mL
Estimate against measurement, compound 4: 11-fold (1.03 log units) above; measured number below the stated range.
By their numbers in this assay, from the lowest: compounds 1, 4 and 3 (each within the scatter of the next); then compound 2.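

In this assay the step of a 26-fold lower number from compound 2 to compound 4 (1.41 log units; beyond the scatter) is large, and the change behind it is only methyl in place of hydrogen on a saturated chain carbon bound to a carbonyl carbon. The other two steps, a 1.6-fold lower number from compound 3 to compound 4 (0.21 log units; within the scatter) and a 1.1-fold higher number from compound 1 to compound 4 (0.03 log units; within the scatter), both lie within the scatter, so ethyl, cyclopentyl and 2-fluorophenyl on this carbonyl carbon cannot be told apart on this read-out, despite the ring and carbon counts that separate them. Across these four compounds the numbers therefore do not track carbon count stepwise: compound 2 alone stands apart, and no evidence shown here gives a cause for that split.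

Still open, from the compounds shown here alone, is how methyl compares with a hydrogen or a methoxymethyl group on the same carbonyl carbon, and whether a cyclopropyl group or a longer chain such as butyl stays with compound 4 or moves toward compound 2 at 83.9 ug/mL in this assay. Also open, going by these compounds, is whether an amine or a carboxylic acid on an ethyl-sized chain would separate from compound 4 at all.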